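The compounds below may be only part of what the source reports. "The series", "measured", "known", "first", "only" and "open" are said of these compounds alone.

Measured compounds:
compound 1 `CC(=O)OC[C@H]1O[C@@H](CC(=O)/C=C/c2cccnc2)[C@H](OC(C)=O)[C@@H](OC(C)=O)[C@@H]1OC(C)=O` — 4.17 nM
compound 2 `COc1ccccc1/C=C/C(=O)C[C@@H]1O[C@H](COC(C)=O)[C@@H](OC(C)=O)[C@H](OC(C)=O)[C@H]1OC(C)=O` — "not determined" (no result reported)
compound 3 `CC(=O)OC[C@H]1O[C@@H](CC(=O)/C=C/c2cc(Cl)cc(Cl)c2O)[C@H](OC(C)=O)[C@@H](OC(C)=O)[C@@H]1OC(C)=O` — "not determined" (no result reported)

In an ADME assay on cells (Epithelial cell, Homo sapiens) for cytotoxicity, read by MTT assay, with a stated time of 24 h (a lower number here means that less compound is tolerated, a higher number that more compound is tolerated), compound 1 gives 4.17 nM. For compound 2 the outcome in this assay is "not determined" (no result reported), and for compound 3 it is likewise "not determined" (no result reported), so no single number stands for compound 3, and one further member of the series, compound 2, shares that position. Where compound 3 stands can therefore only be read from compound 1, the sole member with a measured result, whose value is low.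

Compound 4 `CC(=O)OC[C@H]1O[C@@H](CC(=O)/C=C/c2cccc([N+](=O)[O-])c2)[C@H](OC(C)=O)[C@@H](OC(C)=O)[C@@H]1OC(C)=O` is not yet measured. It differs from compound 3 in one place: 3-nitrophenyl in place of 3,5-dichloro-2-hydroxyphenyl on a double-bonded chain carbon bound to a double-bonded chain carbon. Among the measured compounds shown here, with no measured pair to set the size of this step, the expectation rests on compound 1 alone, and any shift for compound 4 relative to compound 3 cannot be given a direction; a step not beyond the scatter is the working assumption.

On that basis compound 4 is expected to give about 5 nM in this assay, estimated to fall between 1.5 nM and 17 nM.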

Compound 4, half-maximal cytotoxic concentration: 15.5 nM
Beside the measured number, compound 4's estimate is 3.1-fold (0.49 log units) below it, within the range that was stated.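

In this assay the group on a double-bonded chain carbon bound to a double-bonded chain carbon now has a first readable exchange: 3-nitrophenyl in place of pyridin-3-yl gives a 3.7-fold higher number from compound 1 to compound 4 (0.57 log units; beyond the scatter) on an otherwise unchanged core. This pair shows that the number responds to a change at this position, with more compound tolerated for the 3-nitrophenyl member than for the pyridin-3-yl member. Nothing measured on these compounds bears on what lies behind the shift.

Steps involving compound 2 or compound 3 cannot be read, since neither compound has a number in this series. On these data alone, whether an amine or a carboxylic acid in place of the nitro group of 3-nitrophenyl would move the number further, and in which direction, remains open.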